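The source may report more compounds than this note shows. Statements on the series, on what has been measured and on what is new or still open speak of the compounds shown alone.

Measured compounds:
compound 1, `Nc1ccccc1-c1cnc(C(=O)CCCCCCc2ccccc2)o1`, 750 nM in an assay (Rattus norvegicus) for inhibition of Fatty-acid amide hydrolase 1 (Homo sapiens); a higher number here means a weaker inhibitor, a lower number a stronger inhibitor;
compound 2, `COc1ccccc1-c1cnc(C(=O)CCCCCCc2ccccc2)o1`, 400 nM in this assay.

Among the measured compounds shown here, compound 2 stands beside compound 1 as the only other measured compound, and the two are separated by a 1.9-fold lower number from compound 1 to compound 2 (0.27 log units; within the scatter), so neither can be called the stronger inhibitor on this evidence. Compound 3, `Cc1cccnc1-c1cnc(C(=O)CCCCCCc2ccccc2)o1`, has not yet been measured in this assay. It differs from compound 2 in one place: 3-methylpyridin-2-yl in place of 2-methoxyphenyl on an aromatic carbon.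

For the measured compounds named here, the only measured step that bears on this change is the one from compound 1 to compound 2, which also alters the group on the same aromatic carbon of the shared core and gave a 1.9-fold lower number from compound 1 to compound 2 (0.27 log units; within the scatter). That step was small, and nothing in the data shows that an exchange of one six-membered aromatic ring for another at this position moves the inhibition constant beyond the scatter. The expected step from compound 2 to compound 3 is therefore a 1.3-fold higher number from compound 2 to compound 3 (0.10 log units; within the scatter), that is, none beyond the scatter. Compound 3 is estimated to give 500 nM in this assay, with a range from 150 nM to 1600 nM.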

Compound 3, inhibition constant: 15 nM
Estimate against measurement, compound 3: 33-fold (1.52 log units) above; measured number outside the range, below it.
By their numbers in this assay, from the lowest: compound 3; then compounds 2 and 1 (each within the scatter of the next).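

In this assay the aromatic carbon next to the ring oxygen proves to be a place where the inhibition constant can move well beyond the scatter: 3-methylpyridin-2-yl in place of 2-methoxyphenyl brings a 27-fold lower number from compound 2 to compound 3 (1.43 log units; beyond the scatter) and, in place of 2-aminophenyl, it brings a 50-fold lower number from compound 1 to compound 3 (1.70 log units; beyond the scatter) as well. The exchange of amino for methoxy on the phenyl ring had shown no change beyond the scatter, so compound 3 is the first sign that the identity of the six-membered aromatic ring at this place can matter, and its steps to both other compounds are printed as beyond the scatter. No measurement offered here explains why the number falls so far.

The entering group differs from the leaving ones in both its ring nitrogen and its methyl, so the compounds shown leave open how much each contributes, a question that plain pyridin-2-yl and 2-methylphenyl would address. From the compounds shown here alone, it also remains open whether a chloro or a carboxylic acid on the pyridine ring would keep the low number, and whether the same exchange holds with a shorter chain on the carbonyl.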